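A few compounds are considered here, and "the series" means these few. Any claim that something is new, unique, unknown or untested is made for them only; others in the source may bear on it.

Compound 1 `OCC(O)Cn1nc2c(Br)c(Br)c(Br)c(Br)c2n1` carries a 1,2-dihydroxyethyl group on the saturated chain carbon bound to the aromatic nitrogen of the shared core. In a functional assay on MCF7 cells (Homo sapiens) for antiproliferative activity, read by MTT assay, with a stated time of 24 h, tested at 25 uM (a higher number here means a weaker effect of the compound at the concentration tested, a lower number a stronger effect), compound 1 gives 156%, the higher of the two numbers recorded. Compound 2 `OC(CCn1nc2c(Br)c(Br)c(Br)c(Br)c2n1)c1ccccc1` gives 99% in this assay, a gap beyond the usual scatter. Compound 3 `C[C@H](O)CCn1nc2c(Br)c(Br)c(Br)c(Br)c2n1` has not yet been measured; it differs from compound 1 by 2-hydroxypropyl in place of 1,2-dihydroxyethyl on a saturated chain carbon bound to an aromatic nitrogen. Among the measured compounds shown here, no measured pair isolates this change, so its size in this assay is open; a modest downward step, near the edge of the scatter, is expected. For compound 3 the expected value is 135%, within 100% to 170%. This corresponds to an expected step of a number 21 percentage points lower from compound 1 to compound 3 (beyond the scatter).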

Compound 3, a percentage reported as activity, at one concentration (the size of the read-out at that concentration, not a potency): 102%
Compound 3: the middle estimate sits 33 percentage points above what was measured; the range from low to high includes it.
By their numbers in this assay, from the lowest: compounds 2 and 3 (each within the scatter of the next); then compound 1.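

In this assay, 2-hydroxypropyl in place of 1,2-dihydroxyethyl on a saturated chain carbon bound to an aromatic nitrogen gives a step of a number 54 percentage points lower from compound 1 to compound 3 (beyond the scatter) and so shows that this position responds strongly to this single change. Compound 3 at 102% and compound 2 at 99% lie within the scatter of each other. No measurement here explains the step. From the compounds shown here alone, an amine or a carboxylic acid at this position remains open, and so does the mirror-image form of compound 3.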